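The source may hold more compounds than are shown below. What is called first, only, known or untested is meant among the compounds shown, and "the series" means these compounds.

Working notes on the series. In a functional assay on MCF7 cells (Homo sapiens) for antiproliferative activity, read by MTT assay, with a stated time of 24 h (a higher number here means a weaker inhibitor, a lower number a stronger inhibitor), compound 1 (`CCCCc1oc2ccccc2c1C(=O)c1ccc(OCC(=O)N2CCCC2)cc1`) gives 42400 nM, compound 2 (`CCCCc1oc2ccccc2c1C(=O)c1ccc(OCC(=O)N2CCN(C(=O)OC(C)(C)C)CC2)cc1`) gives 42200 nM and compound 3 (`CCCCc1oc2ccccc2c1C(=O)c1ccc(OCC(=O)Nc2ccccc2)cc1`) gives 33600 nM. The value of compound 3 lies within the scatter of both others, so the three compounds stand at one level and no ranking can be drawn among them.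

Compound 4 (`CCCCc1oc2ccccc2c1C(=O)c1ccc(OCCCC(=O)N2CCCCC2)cc1`) has not yet been measured. Its difference from compound 3 is 2-((piperidin-1-yl)carbonyl)ethyl in place of phenylcarbamoyl on a saturated chain carbon bound to an oxygen on an aromatic ring. In short, 2-((piperidin-1-yl)carbonyl)ethyl stands in place of phenylcarbamoyl on a saturated chain carbon bound to an oxygen on an aromatic ring.

Within the data shown here, one measured step bears on this change: a 1.3-fold lower number from compound 1 to compound 3 (0.10 log units; within the scatter), with anilino in place of pyrrolidin-1-yl on a carbonyl carbon. That step stays within the scatter. Compound 2, with yet another group on that carbonyl carbon, also stays at this level with 42200 nM. Among the measured compounds shown here, no measured pair isolates a change in chain length, so that part of the change has no direct support in the data.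

No step beyond the scatter is therefore expected in this assay, and no firm direction is expected. The estimated step is a 1.1-fold higher number from compound 3 to compound 4 (0.05 log units; within the scatter). Compound 4 is estimated at 38000 nM, with an expected range of 20000 nM to 70000 nM.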

Compound 4, half-maximal inhibitory concentration: 33000 nM
The estimate for compound 4 lay 1.2-fold (0.06 log units) above the measured number; measured number inside the range.
By their numbers in this assay, from the lowest: compounds 4, 3, 2 and 1 (each within the scatter of the next).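

In this assay, the step of a 1.0-fold lower number from compound 3 to compound 4 (0.01 log units; within the scatter) shows that this place, a saturated chain carbon bound to an oxygen on an aromatic ring, can carry 2-((piperidin-1-yl)carbonyl)ethyl instead of phenylcarbamoyl with the number staying within the scatter, although the entering group has 0 hydrogen-bond donors and the leaving group has 1. The second step, a 1.3-fold lower number from compound 1 to compound 4 (0.11 log units; within the scatter), also stays within the scatter and adds what compounds 1, 2 and 3 could not show: the level holds when the chain and the amide ring change together, with 2-((piperidin-1-yl)carbonyl)ethyl in place of (pyrrolidin-1-yl)carbonyl. No measurement shown here speaks to why the four compounds stand at one level.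

Chain length and ring size changed in a single step, so the contribution of each stays open, and a pair with a longer chain that keeps the pyrrolidine amide would separate them. On these data alone, it also remains open whether any group at this place departs from this level, such as a carboxylic acid in place of the amide or a free amine at the end of the chain.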